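From 3,4-dimethoxyphenyl to 4-methoxyphenyl: a prediction for compound 4

The source may report more compounds than this note shows. Statements on the series, on what has been measured and on what is new or still open speak of the compounds shown alone.

Of the compounds shown here, three have been measured in a functional assay on HT-29 cells (Homo sapiens) for antiproliferative activity, read by sulforhodamine B assay, with a stated time of 48 h; on this read-out higher numbers stand for weaker inhibition and lower numbers for stronger inhibition. Compound 1 (`CCCN1CCN(c2ccc(S(=O)(=O)Oc3ccc(OC)cc3)cc2)C1=O`) gives 16000 nM, compound 2 (`CCCCN1CCN(c2ccc(S(=O)(=O)Oc3cccc(F)c3)cc2)C1=O`) gives 76000 nM, and compound 3 (`CCCCN1CCN(c2ccc(S(=O)(=O)Oc3ccc(OC)c(OC)c3)cc2)C1=O`) gives 21000 nM. Compound 3 therefore lies within the scatter of compound 1 and clearly lower than compound 2 on this scale.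

The next compound, compound 4 (`CCCCN1CCN(c2ccc(S(=O)(=O)Oc3ccc(OC)cc3)cc2)C1=O`), differs from compound 3 by a single change: hydrogen in place of methoxy on an aromatic carbon. Hydrogen takes the place of methoxy on an aromatic carbon, ortho to a methoxy group, so 3,4-dimethoxyphenyl becomes 4-methoxyphenyl.

Among the compounds with values here, only one measured step bears on this, a 3.6-fold lower number from compound 2 to compound 3 (0.56 log units; beyond the scatter), which is modest and beyond the scatter. Within the data shown here, it exchanges 3-fluorophenyl for 3,4-dimethoxyphenyl, so it does not isolate a single methoxy, and no measured step removes one alone. The closest guide is compound 1, which carries the same 4-methoxyphenyl group and gives 16000 nM. That value is within the scatter of compound 3, so no step beyond the scatter is expected in this assay. The expected change is a 1.1-fold lower number from compound 3 to compound 4 (0.02 log units; within the scatter), with no firm direction. For compound 4 the estimated value is 20000 nM, with an expected range from 9000 nM to 45000 nM.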

Compound 4, half-maximal inhibitory concentration: 35000 nM
The estimate for compound 4 lay 1.8-fold (0.24 log units) below the measured number, within the range that was stated.
By their numbers in this assay, from the lowest: compounds 1, 3 and 4 (each within the scatter of the next, the first and the last beyond it); then compound 2.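

In this assay, the methoxy ortho to a methoxy group can be replaced by hydrogen without a change beyond the scatter, as shown by a 1.7-fold higher number from compound 3 to compound 4 (0.22 log units; within the scatter), and the step of a 2.2-fold lower number from compound 2 to compound 4 (0.34 log units; beyond the scatter) shows that the difference from the 3-fluorophenyl compound persists without this second methoxy. Within the data shown here, the result also adds the first measured step at the other end of the molecule: a 2.2-fold higher number from compound 1 to compound 4 (0.34 log units; beyond the scatter) comes from methyl in place of hydrogen on a saturated chain carbon, three bonds along the chain from an amide-type nitrogen in a ring, so the chain is a site where a small change goes beyond the scatter, although this rests on a single pair. Nothing available explains either the step at the aromatic carbon or the step on the chain.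

The compounds shown leave open whether a hydroxyl, an amine or a carboxylic acid on the same aromatic carbon would give a number different from that of compound 4. They also leave open whether a longer chain would continue the step seen on the chain, and whether that step would recur with 3,4-dimethoxyphenyl or 3-fluorophenyl on the oxygen.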